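Cytotoxicity notes: isopropyl for cyclopropyl on the amine

The source may report more compounds than this note shows. Statements on the series, on what has been measured and on what is new or still open speak of the compounds shown alone.

Measured compounds:
compound 1 `N#C/C=C/c1ccc(C(NC2CC2)c2ccnc(Nc3ccc(C#N)cc3)n2)cc1` — 56100 nM
compound 2 `CC(O)CNC(c1ccc(C#N)cc1)c1ccnc(Nc2ccc(C#N)cc2)n1` — > 65000 nM
compound 3 `CCCNC(c1ccnc(Nc2ccc(C#N)cc2)n1)c1ccccc1Cl` — 68500 nM

All three were run in an ADME assay on MT4 cells (Homo sapiens) for cytotoxicity, read by MTT assay, with a stated time of 5 days; a higher number here means that more compound is tolerated, a lower number that less compound is tolerated. Compound 1 gives 56100 nM and so holds the lower of the two numbers reported; compound 3 gives 68500 nM, and the gap between compound 1 and compound 3 lies within the scatter, so no order between the two can be read. Compound 2 gives only a limit in this assay, (the limit of > 65000 nM in this assay, at which 1 of the 3 values shown sits), and not a number.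

Going by the values given here, no pair among the measured compounds differs in a single place, so no measured step is available to calibrate the change to compound 4 `CC(C)NC(c1ccc(/C=C/C#N)cc1)c1ccnc(Nc2ccc(C#N)cc2)n1`. The change from compound 1 is isopropyl in place of cyclopropyl on an amine nitrogen.

Among the compounds with values here, with no measured step to lean on, and all three numbers sitting close to or at the top of the measured range, the expectation is that compound 4 shows no step beyond the scatter in this assay: the estimated step is a 1.0-fold higher number from compound 1 to compound 4 (0.01 log units; within the scatter). Compound 4 is therefore expected to give about 58000 nM, between 30000 nM and 90000 nM, with a fair chance that the assay reports only a limit.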

Compound 4, half-maximal cytotoxic concentration: 32300 nM
Compound 4: the middle estimate sits 1.8-fold (0.25 log units) above what was measured; the range from low to high includes it.
By their numbers in this assay, from the lowest: compounds 4, 1 and 3 (each within the scatter of the next, the first and the last beyond it).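

The cyclopropylamino to isopropylamino change gives the series its first step between compounds that differ in one place, and in this assay it reads a 1.7-fold lower number from compound 1 to compound 4 (0.24 log units; within the scatter). At this amine nitrogen, then, replacing the three-membered ring of cyclopropyl with the open isopropyl, with the same count of carbon atoms, gives no step that can be told apart from repeat measurement, so the ring is not shown to matter for this read-out in this pair. This rests on one pair only, and nothing measured here gives a reason for the size of the step.

Going by these compounds, whether a larger ring such as cyclobutyl, a tert-butyl group or a longer chain ending in a carboxylic acid on the same amine nitrogen would give a step beyond the scatter stays open. Also open, on these data alone, is whether the cyclopropyl to isopropyl change reads the same when the rest of the molecule differs from the core of compound 1, since compound 2 and compound 3 carry other groups in more than one place and offer no matched comparison.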